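The compounds below may be only part of what the source reports. "The series", "measured", "known", "first", "only" and "open" are said of these compounds alone.

Among the two compounds measured so far in a functional assay on the whole organism (strain Wistar) for inhibition, with Rattus norvegicus as the target, read by paw edema, with stated times of 60 min and 24 h, at a dose of 100 mg/kg by the oral route (a lower number here means less inhibition, a higher number more inhibition at the dose given (going by the name of the read-out)), compound 2 `CCCCNC(=O)CC1CCc2cc(OC)c(OC)cc21` gives 36.7%, and compound 1 `CNC(=O)CC1CCc2cc(OC)c(OC)cc21` gives 33.3%, a pair within the scatter of each other; the step of a number 3.4 percentage points higher from compound 1 to compound 2 (within the scatter) is the only one recorded, propyl in place of hydrogen on a saturated chain carbon bound to an amide-type nitrogen. Compound 3 `COc1cc2c(cc1OC)C(CC(=O)NC(C)(C)C)CC2` differs from compound 2 by tert-butyl in place of butyl on an amide-type nitrogen. Among the compounds with values here, no measured step bears on such a change, and the one step seen stayed within the scatter, so for compound 3 a step of a number 1.7 percentage points lower from compound 2 to compound 3 (within the scatter) is expected, none beyond the scatter. Compound 3 is estimated at 35%, between 20% and 50%.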

Compound 3, a percentage reported as inhibition, in the whole organism at one dose (the size of the read-out at that dose, not a potency): 40%
The estimate for compound 3 lay 5 percentage points below the measured number, and the stated range covers the measured number.
By their numbers in this assay, from the lowest: compounds 1, 2 and 3 (each within the scatter of the next).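

On the amide-type nitrogen, tert-butyl in place of butyl gives a number 3.3 percentage points higher from compound 2 to compound 3 (within the scatter), and tert-butyl in place of methyl gives a number 6.7 percentage points higher from compound 1 to compound 3 (within the scatter), both read in this assay. The same four carbons, joined as tert-butyl instead of butyl, therefore do not separate these compounds beyond the scatter at this dose. Nothing at hand gives a reason for these numbers.

Going by these compounds, whether a carboxylic acid, an amine or a phenyl ring at this place on the nitrogen would give a number beyond the scatter remains open. So does whether a second alkyl chain in place of the amide hydrogen would do so.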